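Swapping an amide hydrogen for methyl on a shared core

The source may report more compounds than this note shows. Statements on the series, on what has been measured and on what is new or still open speak of the compounds shown alone.

Compound 2 `C[C@H](Nc1c(C(N)=O)nnc2ccc(-c3ccc(OCCCN(C)C)nc3)cc12)C1CCOCC1` and compound 1 `CNC(=O)c1nnc2ccc(-c3ccc(COC)nc3)cc2c1N[C@@H](C)C1CCOCC1` share a core and were both run in an ADME assay on cells (Hepatocyte, Rattus norvegicus) for metabolic stability, read by HPLC, with a stated time of 30 min, tested at 1 uM; on this read-out lower numbers stand for slow clearance and higher numbers for fast clearance. In this assay compound 2 gives 3.4 uL/min. Compound 1 gives 5.8 uL/min, and the gap between the two numbers lies within the usual scatter of repeated runs, so the two compounds cannot be told apart on these data. Compound 1 and compound 2 also differ in more than one place, so nothing is known from them about any single change.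

Compound 3 `CNC(=O)c1nnc2ccc(-c3ccc(OCCCN(C)C)nc3)cc2c1N[C@@H](C)C1CCOCC1` has not yet been measured. It differs from compound 2 by one change: methyl in place of hydrogen on an amide-type nitrogen. Read one bond further out, carbamoyl becomes methylcarbamoyl. Among the measured compounds shown here, no pair of measured compounds isolates this change, so the expectation for compound 3 rests on the two numbers above alone. The step from compound 2 to compound 3 is expected to be small, a 1.3-fold higher number from compound 2 to compound 3 (0.12 log units; within the scatter), and not beyond the scatter in either direction. Compound 3 is therefore estimated at 4.5 uL/min, with a plausible range from 2.3 uL/min to 9 uL/min.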

Compound 3, intrinsic clearance in a liver preparation (reported as CLH), per the amount of preparation that the assay uses: 5.7 uL/min
The estimate for compound 3 lay 1.3-fold (0.10 log units) below the measured number; measured number inside the range.
By their numbers in this assay, from the lowest: compounds 2, 3 and 1 (each within the scatter of the next).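

In this assay, methyl in place of hydrogen on the amide-type nitrogen now has a measured step of its own, a 1.7-fold higher number from compound 2 to compound 3 (0.22 log units; within the scatter), so carbamoyl and methylcarbamoyl cannot be told apart in this pair. Compound 3 also isolates a second change, 3-(dimethylamino)propoxy in place of methoxymethyl on an aromatic carbon, and this gives a 1.0-fold lower number from compound 1 to compound 3 (0.01 log units; within the scatter). The earlier pair differed in more than one place and could say nothing about either change, whereas each can now be read alone, and neither moves the number beyond the scatter in this assay. No measurement is available that could explain these results.

On these data alone, the methyl step has been read only on compounds carrying 3-(dimethylamino)propoxy, so its size alongside methoxymethyl remains open. Also open, as far as these compounds go, is whether a longer chain such as ethyl or propyl, a ring such as cyclopropyl, or a second methyl on the same nitrogen would stay within the scatter or produce a clear step in this assay.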